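The source may hold more compounds than are shown below. What is called first, only, known or untested is meant among the compounds shown, and "the series" means these compounds.

Compound 3 `CCCNC(=O)c1cc(Oc2ccc(NC(=O)c3cc4cccnc4n(-c4ccc(F)cc4)c3=O)cc2)ccn1` gives the lowest of the three numbers in a functional assay on A549 cells (Homo sapiens) for antiproliferative activity, read by MTT assay, with a stated time of 72 h; on this read-out higher numbers stand for weaker inhibition and lower numbers for stronger inhibition. Within the data shown here, compound 2 `CCNC(=O)c1cc(Oc2ccc(NC(=O)c3cc4cccnc4n(-c4ccc(F)cc4)c3=O)cc2)ccn1` gives 120 nM, and compound 3 gives 62 nM; the only step that separates them, a 1.9-fold lower number from compound 2 to compound 3 (0.29 log units; within the scatter), is a methyl in place of hydrogen on a saturated chain carbon, two bonds along the chain from an amide-type nitrogen. Among the measured compounds shown here, compound 1 `CNC(=O)c1cc(Oc2ccc(NC(=O)c3cc4cccnc4n(-c4ccc(Br)cc4F)c3=O)cc2)ccn1` gives 1420 nM, a number far beyond the scatter from compound 3, but compound 1 differs from compound 3 in more than one place, so no single step can be drawn from it.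

Compound 4 `CCCNC(=O)c1cc(Oc2ccc(NC(=O)c3cc4cccnc4n(-c4ccc(Br)cc4F)c3=O)cc2)ccn1` carries the change (4-bromo-2-fluorophenyl in place of 4-fluorophenyl on an aromatic nitrogen). For the measured compounds named here, no measured pair isolates this change. Compound 1 carries the same 4-bromo-2-fluorophenyl group and a shorter chain on its amide-type nitrogen; since the chain step from compound 2 to compound 3 stayed within the scatter, much of the gap between compound 1 and compound 3 is plausibly tied to the aromatic group, though this is not proven by a direct pair.

A rise in the number is therefore expected in this assay, with the step from compound 3 to compound 4 estimated at a 9.7-fold higher number from compound 3 to compound 4 (0.99 log units; beyond the scatter). Compound 4 is estimated at 600 nM, with a range from 150 nM to 2500 nM.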

Compound 4, half-maximal inhibitory concentration: 1310 nM
Estimate against measurement, compound 4: 2.2-fold (0.34 log units) below, and the stated range covers the measured number.
By their numbers in this assay, from the lowest: compounds 3 and 2 (each within the scatter of the next); then compounds 4 and 1 (each within the scatter of the next).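

In this assay, the direct pair shows that 4-bromo-2-fluorophenyl in place of 4-fluorophenyl on the aromatic nitrogen weakens inhibition by a large margin (a 21-fold higher number from compound 3 to compound 4 (1.32 log units; beyond the scatter)), which turns the earlier inference from compounds that differed in more than one place into a measured step. With 4-bromo-2-fluorophenyl held constant, the longer chain on the amide-type nitrogen of compound 4 leaves the number within the scatter of that of compound 1 (a 1.1-fold lower number from compound 1 to compound 4 (0.04 log units; within the scatter)), so among these compounds, the aromatic group rather than the chain marks the large gap. No measurement shown here explains the loss of inhibition.

The swap adds bromine and a second fluorine in one step, so the compounds shown leave open which of the two carries the change; a 4-bromophenyl group or a 2,4-difluorophenyl group on the same nitrogen would help to separate them. Going by these compounds, it also remains open how a longer chain such as butyl, or a chain ending in an amine, would behave on the amide-type nitrogen with either aromatic group.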